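The source may hold more compounds than are shown below. What is called first, only, known or untested is meant among the compounds shown, and "the series" means these compounds.

Compound 3 `CC(C)=CCCC1=CC[C@H](C(=O)Nc2ccc(C(=O)O)cc2)[C@@H](c2ccccc2)C1` gives, in an assay on isolated protein for inhibition of Apoptosis regulator Bcl-2 (Homo sapiens), read by fluorescence polarization, with stated times of 5 min and 10 min (a lower number here means a stronger inhibitor, a higher number a weaker inhibitor), only a limit of the assay, > 23000 nM. Compound 1 `COC(=O)c1ccc(NC(=O)[C@H]2CC=C(CCC=C(C)C)C[C@@H]2c2ccccc2)cc1` likewise reaches only a limit, > 23000 nM. Compound 2 `COC(=O)CCNC(=O)[C@H]1CC=C(CCC=C(C)C)C[C@@H]1c1ccccc1`, by contrast, gives a number in this assay, 3100 nM. Both of the others sit at the limit of > 23000 nM in this assay, at which 2 of the 3 values shown sit, so compound 3 stands at the weak end of what is shown, and the step towards it is read only as an at-least figure: an at least 7.4-fold higher number from compound 2 to compound 3 (0.87 log units; beyond the scatter).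

Compound 4 `CC(C)=CCCC1=CC[C@H](C(=O)NCCC(=O)O)[C@@H](c2ccccc2)C1` differs from compound 3 in one place: 2-carboxyethyl in place of 4-carboxyphenyl on an amide-type nitrogen. The measured steps that bear on this change are an at least 7.4-fold lower number from compound 1 to compound 2 (0.87 log units; beyond the scatter), where an aryl group on the amide-type nitrogen was also exchanged for a chain carrying the same carbonyl group, and the reverse-direction an at least 7.4-fold higher number from compound 2 to compound 3 (0.87 log units; beyond the scatter). As far as these compounds go, the exchange of methyl for hydrogen on the oxygen, a step that the two limits leave unreadable from compound 1 to compound 3, gives no readable size, so whether the acid itself shifts the number is unknown. The aryl-to-chain exchange, however, twice moved the number in favour of the chain. Compound 4 is therefore expected to show an at least 3.8-fold lower number from compound 3 to compound 4 (0.58 log units; beyond the scatter). For compound 4 the estimate in this assay is 6000 nM, with a range from 1500 nM to 25000 nM.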

Compound 4, inhibition constant: > 23000 nM
Compound 4 ended at the assay's limit (the forecaster's own chance of this, stated with the estimate: 30%); middle value at least 3.8-fold (0.58 log units) away from the limit.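

The exchange of methyl for hydrogen on the ester oxygen, which could not be sized on the aryl amides, now has a readable size on the chain: an at least 7.4-fold higher number from compound 2 to compound 4 (0.87 log units; beyond the scatter). In this assay, the 2-carboxyethyl chain therefore does not by itself give a measurable number, since a number appears among these compounds only where the chain carries the methyl ester, while the steps from compound 3 and from compound 1 to compound 4 cannot be read, as both ends of each are limits. Compound 2 is thus the only compound shown that gives a number, and the others sit together at one limit: the limit of > 23000 nM in this assay, at which 3 of the 4 values shown sit.

How far compound 3 and compound 4 lie beyond that limit remains open, so any difference between 4-carboxyphenyl and 2-carboxyethyl among the carboxylic acids, and between the two groups among the methyl esters beyond the step already shown, is not settled. Also open, as far as these compounds go, is whether a longer chain carrying the same ester, or a chain carrying a primary amide or an amine in place of the ester, would keep a measurable number or lower it.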